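This account rests on a few compounds, and the source may have more. Where it says the series, first, only, none or still open, it means among the compounds named here.

In a functional assay on NCI-H1650 cells (Homo sapiens) for cytotoxicity, read by MTT assay, with a stated time of 48 h (on this read-out higher numbers stand for weaker inhibition and lower numbers for stronger inhibition), compound 1 `CCCCOc1ccc2c(Cl)ccnc2c1` gives 2570 nM, the second highest of the three numbers. Compound 2 `Clc1ccnc2cc(OCc3ccccc3)ccc12` gives 2720 nM, and compound 3 `Clc1ccnc2cc(OCCCc3ccccc3)ccc12` gives 630 nM. The step of a 1.1-fold higher number from compound 1 to compound 2 (0.02 log units; within the scatter) lies within the scatter, whereas a 4.1-fold lower number from compound 1 to compound 3 (0.61 log units; beyond the scatter) is modest. Compound 4 `CC(C)Oc1ccc2c(Cl)ccnc2c1` differs from compound 1 by isopropyl in place of butyl on an oxygen on an aromatic ring. Neither measured step bears directly on this change: both add a phenyl to the chain, while here the chain is shortened and branched. Going by the values given here, with no measured step to rest on, compound 4 is expected to stay close to compound 1, with a 1.2-fold higher number from compound 1 to compound 4 (0.10 log units; within the scatter) as the estimated step in this assay. Compound 4 is therefore estimated at 3200 nM, with a range from 1200 nM to 8500 nM.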

Compound 4, half-maximal inhibitory concentration: 2310 nM
Beside the measured number, compound 4's estimate is 1.4-fold (0.14 log units) above it; the measured number falls inside the stated range.
By their numbers in this assay, from the lowest: compound 3; then compounds 4, 1 and 2 (each within the scatter of the next).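

The step of a 1.1-fold lower number from compound 1 to compound 4 (0.05 log units; within the scatter) in this assay shows that isopropyl in place of butyl on an oxygen on an aromatic ring, a change that adds no phenyl, leaves the number within the scatter. At this position, the butyl and isopropyl chains therefore do not separate in this assay. No evidence on the reason is available here.

The compounds shown leave open whether a longer chain, or an amine or a carboxylic acid at the end of the chain, would stay near compound 1 or move as far as compound 3.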